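Ester in place of acid on the pyrazole of compound 2

The source may hold more compounds than are shown below. What is called first, only, known or untested is meant among the compounds shown, and "the series" means these compounds.

Measured compounds:
compound 1 `CCOC(=O)c1cnn(-c2nc(NC3CCCCC3)c3ncn([C@@H]4O[C@H](CO)[C@@H](O)[C@H]4O)c3n2)c1`, 30 nM
compound 2 `O=C(O)c1cnn(-c2nc(NC34CCC(CC3)C4)c3ncn([C@@H]4O[C@H](CO)[C@@H](O)[C@H]4O)c3n2)c1`, 1 nM

In an assay on cell membranes (Cricetinae) for displacement of a labelled ligand from adenosine receptor A1 (Homo sapiens) (a higher number here means a weaker inhibitor, a lower number a stronger inhibitor), compound 2 gives 1 nM, the lowest number of the two, while compound 1 gives 30 nM. Compound 3 `CCOC(=O)c1cnn(-c2nc(NC34CCC(CC3)C4)c3ncn([C@@H]4O[C@H](CO)[C@@H](O)[C@H]4O)c3n2)c1` is not yet measured. It differs from compound 2 in one place: ethyl in place of hydrogen on an oxygen next to a carbonyl group. Going by the values given here, no single step of this kind has been measured here, so the author expects compound 3 to come out weaker than compound 2, with a step of a 5.0-fold higher number from compound 2 to compound 3 (0.70 log units; beyond the scatter) beyond the scatter but short of the gap to compound 1. The estimate for compound 3 in this assay is 5 nM, within 1.5 nM to 20 nM.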

Compound 3, inhibition constant: 3 nM
The estimate for compound 3 lay 1.7-fold (0.22 log units) above the measured number, within the range that was stated.
By their numbers in this assay, from the lowest: compound 2; then compound 3; then compound 1.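

In this assay the change from carboxy to ethoxycarbonyl gives a 3.0-fold higher number from compound 2 to compound 3 (0.48 log units; beyond the scatter) and so shows that ethyl on this oxygen shifts the number by a measurable but limited step. With the ethoxycarbonyl group held constant, changing the group on a nitrogen on an aromatic ring gives a 10-fold lower number from compound 1 to compound 3 (1.00 log units; beyond the scatter) as a larger step, which separates the two changes that compounds 1 and 2 combined. Nothing available here explains either step.

On these data alone, it remains open how a methyl ester, a primary amide or a longer chain would behave in this assay at this position.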